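Three sulfonamides and a difluorophenyl neighbour

A few compounds are considered here, and "the series" means these few. Any claim that something is new, unique, unknown or untested is made for them only; others in the source may bear on it.

Compound 1 `O=S(=O)(Nc1cccc(Cl)c1)c1ccc(-c2cnc(C3CC3)o2)cc1`: 54200 nM
Compound 2 `O=S(=O)(Nc1ccc(Br)c(Cl)c1)c1ccc(-c2cnc(C3CC3)o2)cc1`: 70300 nM
Compound 3 `Cc1ccc(NS(=O)(=O)c2ccc(-c3cnc(C4CC4)o3)cc2)cc1C`: > 100000 nM

All three values come from a functional assay on cells (leukaemia cell line, Homo sapiens) for inhibition, read by sulforhodamine B assay, with a stated time of 48 h; a lower number here means a stronger inhibitor of growth, a higher number a weaker inhibitor of growth. Compound 3 stands at > 100000 nM, which is a limit of the assay and not a number. It is the only one of the three for which this assay gives no number.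

Compound 4 `O=S(=O)(Nc1cc(F)cc(F)c1)c1ccc(-c2cnc(C3CC3)o2)cc1` has not yet been measured. It carries 3,5-difluorophenyl in place of 3,4-dimethylphenyl on a sulfonamide nitrogen.

Two measured steps change the group at that same place: an at least 1.8-fold higher number from compound 1 to compound 3 (0.26 log units; that floor lies within the scatter), and an at least 1.4-fold higher number from compound 2 to compound 3 (0.15 log units; that floor lies within the scatter). Neither step shows a difference beyond the scatter, so they give only weak guidance. The step between the two halogen-bearing compounds, a 1.3-fold higher number from compound 1 to compound 2 (0.11 log units; within the scatter), is also within the scatter. Compound 4 has halogens on its ring too, so it is expected to read close to compound 1 at 54200 nM and compound 2 at 70300 nM. A further limit remains possible for compound 4.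

Within the data shown here, the estimated change is an at least 1.4-fold lower number from compound 3 to compound 4 (0.15 log units; that floor lies within the scatter), and no step clearly beyond the scatter is expected. For compound 4 the estimated value is 70000 nM, with an expected range from 38000 nM to 100000 nM.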

Compound 4, concentration for total growth inhibition: 80000 nM
Compound 4: middle estimate off by 1.1-fold (0.06 log units), on the low side; the measured number falls inside the stated range.
By their numbers in this assay, from the lowest: compounds 1, 2 and 4 (each within the scatter of the next). At a limit, above all of these: compound 3.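

In this assay, compound 4 joins the other halogen-bearing compounds in giving a number at this place on a sulfonamide nitrogen, while the ring with two methyl groups in compound 3 remains the only one at a limit of the assay: the limit of > 100000 nM in this assay, at which 1 of the 4 values shown sits. Even so, the swap of 3,4-dimethylphenyl for 3,5-difluorophenyl is not shown to be a real difference (an at least 1.2-fold lower number from compound 3 to compound 4 (0.09 log units; that floor lies within the scatter)), as the limit gives only a floor for this step. Fluorine at two places on the ring also reads alike with bromine and chlorine together (a 1.1-fold higher number from compound 2 to compound 4 (0.06 log units; within the scatter)) and with chlorine alone (a 1.5-fold higher number from compound 1 to compound 4 (0.17 log units; within the scatter)), so the kind and number of halogens shown here make no difference that stands out from the scatter.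

Going by these compounds, all four compounds carry only halogens or methyl groups on this ring, so it remains open whether any group here can move the number clearly beyond the scatter. On these data alone, an amine or a carboxylic acid on the ring, or a longer chain in its place, would test this, and the shared core stays the same throughout, so what a change there would do is also open.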